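From Methyl to Chloro in Compound 3

A few compounds are considered here, and "the series" means these few. Any claim that something is new, unique, unknown or untested is made for them only; others in the source may bear on it.

Of the compounds shown here, two have been measured so far in an ADME assay on MDCK cells (Canis lupus familiaris) for cytotoxicity; on this read-out lower numbers stand for higher toxicity in this test and higher numbers for lower toxicity in this test. Compound 1 `CCN(CC)CN1C(=O)/C(=N/NC(=S)Nc2ccc(OC)cc2)c2cc(Cl)ccc21` gives 11100 nM, and compound 2 `CCN(CC)CN1C(=O)/C(=N/NC(=S)Nc2ccc(C)cc2)c2cc(Cl)ccc21` gives 11300 nM. Compound 2 therefore stands level with compound 1: the step is a 1.0-fold higher number from compound 1 to compound 2 (0.01 log units; within the scatter).

Compound 3 `CCN(CC)CN1C(=O)/C(=N/NC(=S)Nc2ccc(Cl)cc2)c2cc(Cl)ccc21` keeps the core of compound 2 and alters a single group: chloro in place of methyl on an aromatic carbon. Chloro takes the place of methyl on an aromatic carbon, so 4-methylphenyl becomes 4-chlorophenyl.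

Within the data shown here, only one measured step bears on this change. It concerns the same aromatic carbon, where methyl in place of methoxy gave a 1.0-fold higher number from compound 1 to compound 2 (0.01 log units; within the scatter). Among the measured compounds shown here, that is thin evidence, as it is a single step and no chloro compound has yet been measured in this assay. Still, it offers no reason to expect a shift beyond the scatter, and no direction can be drawn from it.

The expected change is a 1.1-fold lower number from compound 2 to compound 3 (0.03 log units; within the scatter). Compound 3 is estimated at 10500 nM, with an expected range from 5000 nM to 21000 nM.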

Compound 3, half-maximal cytotoxic concentration: 2400 nM
Compound 3: middle estimate off by 4.4-fold (0.64 log units), on the high side, outside the stated range (below it).
By their numbers in this assay, from the lowest: compound 3; then compounds 1 and 2 (each within the scatter of the next).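

This aromatic carbon is not as indifferent as the first two compounds suggested: swapping methoxy for methyl left the number within the scatter, but chloro moves it clearly in this assay. Replacing methyl with chloro gives a 4.7-fold lower number from compound 2 to compound 3 (0.67 log units; beyond the scatter) and replacing methoxy with chloro gives a 4.6-fold lower number from compound 1 to compound 3 (0.67 log units; beyond the scatter) on the same shared core, so among these three compounds, the 4-chlorophenyl compound 3 stands apart as the one with higher toxicity in this test, while compounds 1 and 2 remain level with each other. Nothing available here shows what sets chloro apart from the other two groups at this carbon.

From the compounds shown here alone, whether this drop belongs to chloro alone remains open, since the three compounds cannot show whether fluoro, bromo, trifluoromethyl or nitrile on the same aromatic carbon would give a number near compound 3 or near compounds 1 and 2. Going by these compounds, it is also open whether moving chloro to another carbon of this ring, or placing a hydroxyl or an amine at the same carbon, would keep the lower number.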